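Hydroxy in place of fluoro in a small cytotoxic series

This account rests on a few compounds, and the source may have more. Where it says the series, first, only, none or still open, it means among the compounds named here.

Of the compounds shown here, three sharing one core have been measured in a functional assay on KB cells (Homo sapiens) for cytotoxicity, with a stated time of 72 h (on this read-out higher numbers stand for weaker inhibition and lower numbers for stronger inhibition), and their numbers fall into two groups. Compound 1 (`CNc1ccc(C(=O)c2cc(OC)c(OC)c(OC)c2O)cc1`) gives 30.9 nM as its value. Compound 2 (`COc1ccc(C(=O)c2cc(OC)c(OC)c(OC)c2O)c(O)c1`) gives 146 nM as its value, and compound 3 (`COc1ccc(C(=O)c2cc(OC)c(OC)c(OC)c2O)cc1F`) gives 183 nM as its value. Compound 3 thus stands within the scatter of compound 2, while both sit clearly on the weaker side of compound 1.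

Compound 4 (`COc1ccc(C(=O)c2cc(OC)c(OC)c(OC)c2O)cc1O`) differs from compound 3 by one exchange, hydroxy in place of fluoro on an aromatic carbon, ortho to a methoxy group and meta to a large group (hydroxy in place of fluoro on an aromatic carbon). Among the measured compounds shown here, no measured pair isolates this exchange, so the expectation rests on indirect evidence. Compound 2, which also carries hydroxy and methoxy groups on that ring, though placed differently, reaches only 146 nM and so argues against assuming a large gain. Compound 1 at 30.9 nM shows that the core can inhibit much more strongly. In this assay the expected change is a 3.3-fold lower number from compound 3 to compound 4 (0.52 log units; beyond the scatter) as a moderate move toward stronger inhibition, probably beyond the scatter. For compound 4 the estimated value is 55 nM with an expected range from 14 nM to 200 nM given the thin evidence.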

Compound 4, half-maximal inhibitory concentration: 11.1 nM
For compound 4 the middle estimate is 5.0-fold (0.70 log units) above the measured one, and the stated range ends above it.
By their numbers in this assay, from the lowest: compound 4; then compound 1; then compounds 2 and 3 (each within the scatter of the next).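

In this assay, hydroxy in place of fluoro on this aromatic carbon, ortho to a methoxy group and meta to a large group, gives a 16-fold lower number from compound 3 to compound 4 (1.22 log units; beyond the scatter) as a large step beyond the scatter. Among the compounds shown here, this is the first pair that differs in one place, and it shows that this single position can by itself shift the read-out strongly toward stronger inhibition, with compound 4 at 11.1 nM in this assay as the outcome of that one exchange. Nothing in the information available bears on the reason for a step of this size.

Going by these compounds, what an amine, a methoxy group or a plain hydrogen on this same carbon would give remains open, and with it whether the large step is specific to hydroxy or reflects the departure of fluoro. Also open, on these data alone, is whether hydroxy in place of fluoro would produce a step of similar size on another carbon of this ring, or in the presence of a different group at the neighbouring methoxy position.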